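A Smaller Group on the Sulfonyl Sulfur

The source may report more compounds than this note shows. Statements on the series, on what has been measured and on what is new or still open speak of the compounds shown alone.

In an ADME assay (liver) for metabolic stability, with Liver microsome (Homo sapiens) as the target, read by LC-MS, using microsomes and NADPH, with a stated time of 5 min, at 37 degrees C (a lower number here means slower removal, a higher number faster removal of the compound), compound 1 `CCn1c([C@@H](C)NS(=O)(=O)c2ccccc2)nc2ccc(C(F)(F)F)cc21` gives 14 mL.min-1.g-1. Compound 2 `CCCn1cc(S(=O)(=O)N[C@H](C)c2nc3ccc(C(F)(F)F)cc3n2CC)c(C)n1` gives > 100 mL.min-1.g-1, which is a limit of the assay and not a number. Compound 3 `CCn1cc(S(=O)(=O)N[C@H](C)c2nc3ccc(C(F)(F)F)cc3n2CC)cn1` keeps the shared core and differs from compound 2 only on a sulfonyl sulfur whose other neighbour is the sulfonamide nitrogen: a group of 7 heavy atoms (5 carbon, 2 nitrogen; one five-membered aromatic ring with 2 hetero atoms) in place of a group of 9 heavy atoms (7 carbon, 2 nitrogen; one five-membered aromatic ring with 2 hetero atoms), on a sulfonyl sulfur. The group that enters is 1-ethyl-1H-pyrazol-4-yl, so the ring type stays and the group becomes smaller.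

Going by the values given here, one measured step bears on this change. It is an at least 7.1-fold higher number from compound 1 to compound 2 (0.85 log units; beyond the scatter), beyond the scatter, and it came when a larger group replaced a smaller one on that same sulfur. This single pair is thin evidence, but it points towards a lower number in this assay as the group shrinks again, and probably not all the way back. The estimated change is an at least 2.5-fold lower number from compound 2 to compound 3 (0.39 log units; beyond the scatter). For compound 3 the expected value is 40 mL.min-1.g-1, within an estimated range from 16 mL.min-1.g-1 to 100 mL.min-1.g-1.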

Compound 3, intrinsic clearance in microsomes: 95 mL.min-1.g-1
Beside the measured number, compound 3's estimate is 2.4-fold (0.38 log units) below it, within the range that was stated.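

Replacing phenyl with 1-ethyl-1H-pyrazol-4-yl on the sulfonyl sulfur gives a 6.8-fold higher number from compound 1 to compound 3 (0.83 log units; beyond the scatter), so in this assay this kind of swap now has a measured size and not only a floor. Trimming the group on the same sulfur, from the larger ring group of compound 2 to 1-ethyl-1H-pyrazol-4-yl, gives an at least 1.0-fold lower number from compound 2 to compound 3 (0.02 log units; that floor lies within the scatter), and with that floor inside the scatter, no drop can be claimed, so the smaller group has not been shown to bring the number back towards that of compound 1. This step cannot be read more closely because the value for compound 2 is a limit of the assay and not a number: the limit of > 100 mL.min-1.g-1 in this assay, at which 1 of the 3 values shown sits.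

Only three groups on this sulfur are shown, so it remains open whether the much lower number of compound 1 belongs to the phenyl ring in particular or would also appear with a pyridine ring. Going by these compounds, it also remains open whether a plain methyl in place of the ethyl on the five-membered ring would move the number in this assay at all.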